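Ring group exchange on compound 1

The source may hold more compounds than are shown below. What is called first, only, known or untested is meant among the compounds shown, and "the series" means these compounds.

For the measured compounds named here, in an ADME assay on microsomes from liver (Rattus norvegicus) for metabolic stability (on this read-out lower numbers stand for a shorter-lived compound and higher numbers for a longer-lived compound), compound 1 `CC(C)C(/C=C1\NC(=O)NC1=O)c1ccc(-c2ccc3cccc(F)c3c2)[nH]c1=O` gives 1.46 h as the only actual number so far. Compound 2 `O=C1NC(=O)/C(=C/C(c2ccc(-c3ccc4cccc(F)c4c3)[nH]c2=O)C2CC2)O1` gives > 3 h as a limit of the assay and not a number. Compound 3 `CC(C)C(c1ccc(-c2ccc3cccc(F)c3c2)[nH]c1=O)C1C(=O)NC(=O)N1C` differs from compound 1 on the saturated chain carbon bound to an aromatic carbon and a saturated chain carbon, where a 3-methyl-2,5-dioxoimidazolidin-4-yl group enters (a group of 8 heavy atoms (4 carbon, 2 nitrogen, 2 oxygen; one five-membered non-aromatic ring with 2 hetero atoms) in place of a group of 8 heavy atoms (4 carbon, 2 nitrogen, 2 oxygen; one five-membered non-aromatic ring with 2 hetero atoms), on a saturated chain carbon bound to an aromatic carbon and a saturated chain carbon). Going by the values given here, no measured step covers this change, so in this assay compound 1 at 1.46 h serves as the anchor and no shift beyond the scatter is expected. The expected move is a 1.2-fold higher number from compound 1 to compound 3 (0.09 log units; within the scatter) as an estimate only. The estimate for compound 3 is 1.8 h with an expected range of 0.8 h to 3 h on this read-out.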

Compound 3, half-life: 0.263 h
Compound 3: middle estimate off by 6.8-fold (0.84 log units), on the high side; the whole stated range lies above it.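

In this assay, 3-methyl-2,5-dioxoimidazolidin-4-yl on the saturated chain carbon bound to an aromatic carbon and a saturated chain carbon gives a 5.6-fold lower number from compound 1 to compound 3 (0.74 log units; beyond the scatter). The read-out therefore responds to the ring group at this place, although both groups hold the same number of heavy atoms and differ in double bonds outside aromatic rings and in hydrogen-bond donors. The data shown give no cause for this step. Open: whether the lost double bond or the methyl carries the step, and how an amine or a carboxylic acid at this place would read.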